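Acylation of the aromatic amine in a hydrazinone series

The compounds below may be only part of what the source reports. "The series", "measured", "known", "first", "only" and "open" are said of these compounds alone.

Measured compounds and their numbers in a functional assay for inhibition, with Homo sapiens as the target; a lower number here means that less compound is needed, a higher number that more compound is needed for the effect:
- compound 1 `Nc1ccc(C2=NNC(=O)CC2)cc1`: 46.4 ug/mL
- compound 2 `CC(=O)Nc1ccc(C2=NNC(=O)CC2)cc1`: 1 ug/mL
- compound 3 `O=C1CCC(c2ccc(NC(=O)CCCl)cc2)=NN1`: 0.98 ug/mL

Compound 1 carries the free amine on the shared core and gives the highest number of the three. Its nearest neighbour is compound 2, reached by a 46-fold lower number from compound 1 to compound 2 (1.67 log units; beyond the scatter); the furthest is compound 3, reached by a 47-fold lower number from compound 1 to compound 3 (1.68 log units; beyond the scatter). The two acylated compounds sit together: a 1.0-fold lower number from compound 2 to compound 3 (0.01 log units; within the scatter).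

The step to compound 4 `C=CCNCC(=O)Nc1ccc(C2=NNC(=O)CC2)cc1` replaces the same hydrogen on the aromatic nitrogen: a group of 7 heavy atoms (5 carbon, 1 nitrogen, 1 oxygen; no ring) in place of a hydrogen atom, on a nitrogen on an aromatic ring. Both measured steps from compound 1 bear on it, since each also puts a carbonyl-bearing group on that nitrogen, and each was large. Going by the values given here, the extension of the acyl chain in compound 3 relative to compound 4 left the number unchanged within the scatter, so the allyl-amine tail is not expected to undo the gain; no measured compound carries a nitrogen on that chain, which leaves some uncertainty.

A large drop is therefore expected, a 31-fold lower number from compound 1 to compound 4 (1.49 log units; beyond the scatter), placing compound 4 near the acylated pair. The estimate for compound 4 in this assay is 1.5 ug/mL, with a range of 0.4 ug/mL to 6 ug/mL.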

Compound 4, half-maximal effective concentration: about 21.5 ug/mL
Beside the measured number, compound 4's estimate is 14-fold (1.16 log units) below it; the measured number lies above the stated range.
By their numbers in this assay, from the lowest: compounds 3 and 2 (each within the scatter of the next); then compound 4; then compound 1.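

In this assay, a carbonyl-bearing group on a nitrogen on an aromatic ring does not by itself secure the large drop seen with compounds 2 and 3: compound 4 goes against that pattern, with only a 2.2-fold lower number from compound 1 to compound 4 (0.33 log units; beyond the scatter). The saturated chain carbon bound to a carbonyl carbon is therefore not indifferent to substitution, as the near-identical pair alone had suggested with a 1.0-fold lower number from compound 2 to compound 3 (0.01 log units; within the scatter); allylamino in place of chloromethyl gives a 22-fold higher number from compound 3 to compound 4 (1.34 log units; beyond the scatter), and allylamino in place of hydrogen gives a 22-fold higher number from compound 2 to compound 4 (1.33 log units; beyond the scatter). No measurement at hand accounts for this rise.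

The compounds shown leave open whether the rise follows the chain nitrogen itself or the allyl group on it, and a methylamino or a dimethylamino group on the same chain carbon would separate the two. A methoxy group there would show whether another heteroatom on the chain gives a similar number, and a longer chain between the carbonyl and the amine would show how far that nitrogen's placement matters.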